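A few compounds are considered here, and "the series" means these few. Any claim that something is new, unique, unknown or untested is made for them only; others in the source may bear on it.

Measured compounds:
- compound 1, `CC[C@@H]1c2cc(Cl)ccc2C(=O)N1c1cncc2c1CCC[C@H]2NC(C)=O`, in an ADME assay on microsomes from liver (Homo sapiens) for metabolic stability, read by LC-MS, using NADPH, with stated times of 10 min and 30 min (on this read-out higher numbers stand for fast clearance and lower numbers for slow clearance), compound 1 sits at the limit < 3.5 mL/min/kg
- compound 2, `CCC1c2cc(Cl)ccc2C(=O)N1c1cccnc1`, in this assay compound 2 gives 6.6 mL/min/kg
- compound 3, `CC1c2cc(Cl)ccc2C(=O)N1c1cccnc1`, in this assay compound 3 gives 12.2 mL/min/kg

Within the data shown here, the value for compound 1 is a limit of this assay and not a number; the measurement reports only that the compound sits at the limit of < 3.5 mL/min/kg in this assay, at which 1 of the 3 values shown sits. The difference between the core of compound 1 and the core of compound 2 is not broken down here.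

Compounds 2 and 3 share a core and differ in one place: hydrogen in place of methyl on a saturated chain carbon bound to a saturated ring carbon. This change gives a 1.8-fold higher number from compound 2 to compound 3 (0.27 log units; within the scatter).

Compound 4, `CC(=O)N[C@@H]1CCCc2c1cncc2N1C(=O)c2ccc(Cl)cc2[C@H]1C`, has not yet been measured in this assay. It differs from compound 1 by the same change, (hydrogen in place of methyl on a saturated chain carbon bound to a saturated ring carbon), at the same place as the change from compound 2 to compound 3.

Because compound 1 is known only as a limit (the limit of < 3.5 mL/min/kg in this assay, at which 1 of the 3 values shown sits), the starting point for compound 4 is itself uncertain. The expectation for compound 4 rests on the measured step of a 1.8-fold higher number from compound 2 to compound 3 (0.27 log units; within the scatter) applied to that limit. The step from compound 1 to compound 4 is expected to be an at least 1.2-fold higher number from compound 1 to compound 4 (0.10 log units; that floor lies within the scatter). Compound 4 is estimated at 4.5 mL/min/kg in this assay, with a plausible range from 2 mL/min/kg to 10 mL/min/kg, and there is a fair chance that compound 4 again returns only a limit rather than a number.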

Compound 4, clearance: < 3.5 mL/min/kg
Compound 4: a limit, no number; the forecaster's own chance of this, stated with the estimate: 45%; middle value at least 1.2-fold (0.10 log units) away from the limit.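

Compound 1 and compound 4 both return a limit of the assay rather than a number, so no step can be read between them: the limit of < 3.5 mL/min/kg in this assay, at which 2 of the 4 values shown sit.

The compounds shown leave open what the actual clearance of compound 1 and compound 4 is, and whether changing ethyl to methyl makes any difference to clearance on the core of compound 1.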